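Solubility notes: an added hydroxy on two related cores

The source may report more compounds than this note shows. Statements on the series, on what has been measured and on what is new or still open speak of the compounds shown alone.

Compound 1 `O=C(/C=C/c1ccc(O)c(O)c1)CC(=O)/C=C/c1cc(O)ccc1O`, compound 2 `O=C(/C=C/c1cccc(O)c1)CC(=O)/C=C/c1cc(O)ccc1O` and compound 3 `O=C(/C=C/c1cccc(O)c1)/C=C/c1ccc(O)c(O)c1` have been measured in a physicochemical assay for solubility, using the shake flask method, with a stated time of 12 h; on this read-out higher numbers stand for higher solubility and lower numbers for lower solubility; compound 4 `O=C(/C=C/c1ccc(O)c(O)c1)/C=C/c1cc(O)ccc1O` has not. Compound 2 gives 5800 nM and compound 1 gives 54000 nM. The step of a 9.3-fold higher number from compound 2 to compound 1 (0.97 log units; beyond the scatter) comes from the change (hydroxy in place of hydrogen on an aromatic carbon). Compound 3 gives 60000 nM; how its core differs from the core of compound 2 is not broken down here. Compound 4 arises from compound 3 by the change (hydroxy in place of hydrogen on an aromatic carbon). The surroundings differ: earlier the new group sat ortho to a hydroxy group and para to a large group, here ortho to a large group and para to a hydroxy group, so this is the same kind of change, not the same change. An expected step of a 2.5-fold higher number from compound 3 to compound 4 (0.40 log units; beyond the scatter) in this assay rests on a 9.3-fold higher number from compound 2 to compound 1 (0.97 log units; beyond the scatter), tempered for the different place. The estimate for compound 4 is 150000 nM, between 45000 nM and 500000 nM.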

Compound 4, solubility: 123000 nM
Compound 4: the middle estimate sits 1.2-fold (0.09 log units) above what was measured; the range from low to high includes it.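

In this assay the change of hydrogen to hydroxy gives a 2.1-fold higher number from compound 3 to compound 4 (0.31 log units; beyond the scatter) and, on the other core, a 9.3-fold higher number from compound 2 to compound 1 (0.97 log units; beyond the scatter) in the same direction, each beyond the scatter. The new group sits at a different place in the two pairs, so these two pairs show a shared direction only, not a size that carries over from one core to the other or a rule for the whole series. No measurement at hand gives a reason for either step.

From the compounds shown here alone, whether an amine or a carboxylic acid in place of the new hydroxy would move the number the same way on these cores remains open. Also open, going by these compounds, is how a hydroxy at any other place on the ring would behave.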